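This account rests on a few compounds, and the source may have more. Where it says the series, first, only, none or still open, it means among the compounds named here.

Three analogues on one shared core differ only in the aryl group carried on the ring nitrogen: compound 1 `CCS(=O)(=O)Nc1cc(-c2ccc3ncnc(Nc4cccc(F)c4)c3c2)cnc1OC`, compound 2 `CCS(=O)(=O)Nc1cc(-c2ccc3ncnc(Nc4ccc(OC(F)(F)F)cc4)c3c2)cnc1OC` and compound 3 `CCS(=O)(=O)Nc1cc(-c2ccc3ncnc(Nc4ccc(OC)c(Cl)c4)c3c2)cnc1OC`. In a functional assay on SK-HEP1 cells (Homo sapiens) for cytotoxicity, read by sulforhodamine B assay, with a stated time of 72 h (on this read-out lower numbers stand for stronger inhibition and higher numbers for weaker inhibition), compound 1 gives 1850 nM, compound 2 gives 6140 nM and compound 3 gives 2810 nM; compound 3 therefore sits second highest of the three, its number within the scatter of compound 1 and apart from compound 2. The measured aryl swaps read a 3.3-fold higher number from compound 1 to compound 2 (0.52 log units; beyond the scatter), a 1.5-fold higher number from compound 1 to compound 3 (0.18 log units; within the scatter) and a 2.2-fold lower number from compound 2 to compound 3 (0.34 log units; beyond the scatter). Compound 4 `CCS(=O)(=O)Nc1cc(-c2ccc3ncnc(Nc4ccc(F)c(C(=O)OC)c4)c3c2)cnc1OC` differs from compound 3 by 4-fluoro-3-(methoxycarbonyl)phenyl in place of 3-chloro-4-methoxyphenyl on a nitrogen on an aromatic ring. Going by the values given here, no measured step covers a methoxycarbonyl group. Since every aryl swap so far stayed modest, as a 3.3-fold higher number from compound 1 to compound 2 (0.52 log units; beyond the scatter) and a 2.2-fold lower number from compound 2 to compound 3 (0.34 log units; beyond the scatter) show, a similarly small step in this assay is expected, a 1.2-fold higher number from compound 3 to compound 4 (0.10 log units; within the scatter). Compound 4 is expected at 3500 nM, range 1500 nM to 8500 nM.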

Compound 4, half-maximal inhibitory concentration: 5180 nM
For compound 4 the middle estimate is 1.5-fold (0.17 log units) below the measured one; the range from low to high includes it.
By their numbers in this assay, from the lowest: compounds 1, 3, 4 and 2 (each within the scatter of the next, the first and the last beyond it).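

In this assay the methoxycarbonyl group enters on this nitrogen-bound aryl ring without opening a new level, with a 1.8-fold higher number from compound 3 to compound 4 (0.27 log units; within the scatter) and a 1.2-fold lower number from compound 2 to compound 4 (0.07 log units; within the scatter) and only a 2.8-fold higher number from compound 1 to compound 4 (0.45 log units; beyond the scatter) as a step beyond the scatter. The four aryl groups thus fall into one narrow band despite the larger 4-fluoro-3-(methoxycarbonyl)phenyl group. No available measurement accounts for these steps. The compounds shown leave open whether a carboxylic acid or a primary amide in place of the methoxycarbonyl group would leave this band. As far as these compounds go, the separate contribution of the fluorine also remains open.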